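This account rests on a few compounds, and the source may have more. Where it says the series, first, only, none or still open, it means among the compounds named here.

Measured compounds, metabolic stability:

Compound 1 `CCC(CC)C(=O)OCOC(=O)C1=C(S[C@@H]2CN[C@H](C(=O)Nc3cccc(C(=O)O)c3)C2)[C@H](C)[C@@H]2[C@@H]([C@@H](C)O)C(=O)N12`: in an ADME assay for metabolic stability, read by LC-MS, with a stated time of 3 h, at pH 6.5, tested at 50 uM (a lower number here means that less of the compound is left, a higher number that more of the compound is left), compound 1 gives > 95%, which is a limit of the assay.
Compound 2 `C[C@@H](O)[C@H]1C(=O)N2C(C(=O)OCOC(=O)OC3CCCCC3)=C(S[C@@H]3CN[C@H](C(=O)Nc4cccc(C(=O)O)c4)C3)[C@H](C)[C@H]12`: in this assay compound 2 gives > 95%, again a limit.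
Compound 3 `COC(=O)OCOC(=O)C1=C(S[C@@H]2CN[C@H](C(=O)Nc3cccc(C(=O)O)c3)C2)[C@H](C)[C@@H]2[C@@H]([C@@H](C)O)C(=O)N12`: in this assay compound 3 gives > 95%, also a limit.

Compound 2 therefore stands at the limit, alongside the two others. The steps a step that the two limits leave unreadable from compound 1 to compound 2, a step that the two limits leave unreadable from compound 1 to compound 3 and a step that the two limits leave unreadable from compound 2 to compound 3 cannot be sized because of the limit of > 95% in this assay, at which 3 of the 3 values shown sit.

Compound 4 `C[C@@H](O)[C@H]1C(=O)N2C(C(=O)OCOC(=O)OC3CCCCC3)=C(S[C@@H]3CN[C@H](C(=O)Nc4cccc(C(=O)OCOC(=O)OC5CCCCC5)c4)C3)[C@H](C)[C@H]12` differs from compound 2 by ((cyclohexyloxycarbonyl)oxy)methyl in place of hydrogen on an oxygen next to a carbonyl group. All three measured steps bear on this change only in that each is unreadable, so no size can be drawn from them. The step from compound 2 to compound 4 is expected to be a number at least 1 percentage points lower from compound 2 to compound 4 (that floor lies within the scatter), nothing beyond the scatter. Compound 4 is estimated at 94%, between 82% and 99%.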

Compound 4, percent of the compound remaining: > 95%
Compound 4: no number, only a limit (the forecaster's own chance of this, stated with the estimate: 55%); middle value at least 1 percentage points from the limit.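

No step can be read from compound 2 to compound 4, since both values are limits: the limit of > 95% in this assay, at which 4 of the 4 values shown sit.
The compounds shown give no number in this assay, so how they rank among themselves stays open.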